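The source may hold more compounds than are shown below. What is called first, only, known or untested is meant among the compounds shown, and "the series" means these compounds.

Compound 1 `O=C(NCCCCN1CCCCC1)Nc1ccc(-c2ccccn2)nc1`: in a physicochemical assay for solubility, at pH 7.4 (on this read-out lower numbers stand for lower solubility and higher numbers for higher solubility), compound 1 gives 171000 nM
Compound 2 `O=C(NCCCCN1CCCCC1)Nc1ccc(-c2ccccn2)cc1`: in this assay compound 2 gives 153000 nM
Compound 3 `COc1ccccc1-c1ccc(NC(=O)NCCCCN2CCCCC2)cn1`: in this assay compound 3 gives 174000 nM

Compounds 1 and 2 are the two cores; how they differ is not broken down here. From compound 1 to compound 3 the change is 2-methoxyphenyl in place of pyridin-2-yl on an aromatic carbon, and in this assay it made a 1.0-fold higher number from compound 1 to compound 3 (0.01 log units; within the scatter). Compound 4 `COc1ccccc1-c1ccc(NC(=O)NCCCCN2CCCCC2)cc1` is not yet measured. It arises from compound 2 by 2-methoxyphenyl in place of pyridin-2-yl on an aromatic carbon, the same kind of change, though the place differs: in compound 1 the group leaves a six-membered aromatic ring with 1 nitrogen, next to the ring nitrogen, whereas in compound 2 it leaves a six-membered aromatic ring of carbon only. Because the step of a 1.0-fold higher number from compound 1 to compound 3 (0.01 log units; within the scatter) stayed within the scatter, the step from compound 2 to compound 4 is expected to be about as small, a 1.0-fold higher number from compound 2 to compound 4 (0.01 log units; within the scatter). Compound 4 is therefore estimated at 155000 nM, most likely between 80000 nM and 300000 nM.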

Compound 4, solubility: 114000 nM
For compound 4 the middle estimate is 1.4-fold (0.13 log units) above the measured one; measured number inside the range.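

On the core of compound 2, putting 2-methoxyphenyl in place of pyridin-2-yl gave a 1.3-fold lower number from compound 2 to compound 4 (0.13 log units; within the scatter) in this assay, and on the core of compound 1 the same change gave a 1.0-fold higher number from compound 1 to compound 3 (0.01 log units; within the scatter) in the same read-out. Both steps lie within the scatter, so in these two pairs the change carried from one core to the other without a step that can be told from repeat noise, but two pairs cannot show that this holds on any other core. No measurement given here explains these numbers.

The compounds shown leave open whether an amine or a carboxylic acid on that aromatic carbon would also give so small a step. They also leave open what a longer chain elsewhere in the molecule would do.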